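Phenylsulfanyl replacement on the cyclopentyl compound

A few compounds are considered here, and "the series" means these few. Any claim that something is new, unique, unknown or untested is made for them only; others in the source may bear on it.

Within the data shown here, in a functional assay on NCI-H1975 cells (Homo sapiens) for antiproliferative activity, read by MTT assay, with a stated time of 72 h (on this read-out lower numbers stand for stronger inhibition and higher numbers for weaker inhibition), compound 2 (`CN1CCN(c2ccc(Nc3ncc4nc(Sc5ccccc5)n(C5CCCC5)c4n3)cc2)CC1`) gives 5580 nM as the higher of the two numbers so far, and compound 1 (`CN1CCN(c2ccc(Nc3ncc4nc(Sc5ccccc5)n(C5CCOCC5)c4n3)cc2)CC1`) gives 2260 nM as the lower. Compound 3 (`CN1CCN(c2ccc(Nc3ncc4nc([S+]([O-])c5ccccc5)n(C5CCCC5)c4n3)cc2)CC1`) keeps the cyclopentyl group and loses phenylsulfanyl, and a group with no common name enters on the aromatic carbon between two ring nitrogen atoms (a group of 8 heavy atoms (6 carbon, 1 oxygen, 1 sulfur; one six-membered aromatic ring of carbon only) in place of a group of 7 heavy atoms (6 carbon, 1 sulfur; one six-membered aromatic ring of carbon only), on an aromatic carbon). Among the measured compounds shown here, only one measured step exists, a 2.5-fold higher number from compound 1 to compound 2 (0.39 log units; beyond the scatter) (cyclopentyl in place of oxan-4-yl on an aromatic nitrogen). It concerns a different place and says nothing direct about this change. For the measured compounds named here, no measured step gives a direction here, so no shift beyond the scatter is expected in this assay, though one of modest size either way remains possible. The expected step is a 1.1-fold lower number from compound 2 to compound 3 (0.05 log units; within the scatter) (an estimate only). Compound 3 is estimated at 5000 nM (expected range 1500 nM to 16000 nM).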

Compound 3, half-maximal inhibitory concentration: 5110 nM
Compound 3: the middle estimate sits 1.0-fold (0.01 log units) below what was measured, and the stated range covers the measured number.
By their numbers in this assay, from the lowest: compound 1; then compounds 3 and 2 (each within the scatter of the next).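

In this assay, the swap on the aromatic carbon between two ring nitrogen atoms gives a 1.1-fold lower number from compound 2 to compound 3 (0.04 log units; within the scatter), the first step read at this position. With the cyclopentyl group kept, the entering group, which carries one oxygen more than phenylsulfanyl, therefore produces no shift beyond the scatter, whereas the change on the aromatic nitrogen gives a 2.5-fold higher number from compound 1 to compound 2 (0.39 log units; beyond the scatter). No data are available to explain why this swap leaves the number within the scatter.

It remains open whether the same swap stays within the scatter when oxan-4-yl replaces cyclopentyl, as that pair is not among the compounds shown. Also open, going by these compounds, is how this position responds to groups further from phenylsulfanyl, such as phenylsulfonyl, an amine or a carboxylic acid.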